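Cytotoxicity of a pyrazolo-amide series on Vero cells

A few compounds are considered here, and "the series" means these few. Any claim that something is new, unique, unknown or untested is made for them only; others in the source may bear on it.

Compound 1 `Cc1nn2ccccc2c1C(=O)NCc1ccc(N2CCC(c3ccc(OC(F)(F)F)cc3)CC2)cc1` carries no substituent on the six-membered ring of its fused core. In an ADME assay on Vero cells (Chlorocebus sabaeus) for cytotoxicity, read by CCK-8 assay, with a stated time of 72 h (a higher number here means a weaker inhibitor, a lower number a stronger inhibitor), compound 1 gives > 100000 nM, which is a limit of the assay rather than a number. Compound 2 `Cc1nn2ccc(C(C)C)cc2c1C(=O)NCc1ccc(N2CCC(c3ccc(OC(F)(F)F)cc3)CC2)cc1` bears an isopropyl group on that ring, and in this assay compound 2 gives "not determined" (no result reported). So compound 2 has no single value to stand on; the one further value shown in this assay is a limit, (the limit of > 100000 nM in this assay, at which 1 of the 2 values shown sits), and it belongs to compound 1.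

Compound 3 `Cc1nn2ccc(C(F)(F)F)cc2c1C(=O)NCc1ccc(N2CCC(c3ccc(OC(F)(F)F)cc3)CC2)cc1` differs from compound 2 in one place: trifluoromethyl in place of isopropyl on an aromatic carbon, at the position meta to a fused ring, opposite the ring nitrogen and para to a fused ring. For the measured compounds named here, with no number for compound 2 and only a limit for compound 1, no step in this assay is available to measure the change against. The expectation is that the change makes no difference beyond the scatter in this assay, and that compound 3 again sits at the limit, so compound 3 is estimated at 100000 nM, within 20000 nM to 500000 nM.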

Compound 3, half-maximal inhibitory concentration: > 100000 nM
Compound 3 ended at the assay's limit; the forecaster's own chance of this, stated with the estimate: 70%; the middle value lies on the limit itself.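

In this assay compound 3 gives > 100000 nM, which is a limit of the assay and not a number. No step to compound 3 can be read from compound 1 or compound 2: the limit of > 100000 nM in this assay, at which 2 of the 3 values shown sit.

The compounds shown leave open what actual values compound 1 and compound 3 have, and whether isopropyl and trifluoromethyl differ at all in this assay.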